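Methoxy added to the phenoxy end of compound 2

The source may report more compounds than this note shows. Statements on the series, on what has been measured and on what is new or still open speak of the compounds shown alone.

Measured in an assay on isolated protein for binding affinity to Adrenergic receptor alpha-1 (Rattus norvegicus); on this read-out lower numbers stand for stronger inhibition and higher numbers for weaker inhibition:
compound 1, `Cn1ncc2c(c1=O)OCCCN2C(=O)CNCC1COc2ccccc2O1`: > 10000 nM
compound 2, `Cn1ncc2c(c1=O)OCCCN2C(=O)CCNCCOc1ccccc1`: 8900 nM

Compound 1 gives only (the limit of > 10000 nM in this assay, at which 1 of the 2 values shown sits), a limit of the assay rather than a number. Compound 2 therefore stands as the single numeric result in this assay, with 8900 nM. For the measured compounds named here, the two compounds differ in more than one place, so no single step between them is drawn; their values show only that compound 2 yields a number where compound 1 does not.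

Compound 3, `COc1ccccc1OCCNCCC(=O)N1CCCOc2c1cnn(C)c2=O`, is not yet measured. It differs from compound 2 by methoxy in place of hydrogen on an aromatic carbon, ortho to a large group. Going by the values given here, no measured step covers such a change. The step from compound 2 to compound 3 is expected to be a 5.9-fold lower number from compound 2 to compound 3 (0.77 log units; beyond the scatter), toward stronger binding, beyond the usual scatter. For compound 3 the estimate is 1500 nM, within 300 nM to 8000 nM, with a modest chance that this assay again reports only a limit.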

Compound 3, half-maximal inhibitory concentration: 1700 nM
Compound 3: the middle estimate sits 1.1-fold (0.05 log units) below what was measured; low and high end bracket the measured number.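

Methoxy in place of hydrogen on an aromatic carbon, ortho to a large group, gives in this assay a 5.2-fold lower number from compound 2 to compound 3 (0.72 log units; beyond the scatter), the first step in the series that can be read. This place on the phenoxy end therefore accepts a methoxy group and responds to it with stronger binding, which compound 1 and compound 2 alone could not show. Nothing at hand gives a cause for this step.

One open question is whether the step belongs to methoxy itself or would also follow from a fluorine, a hydroxyl or an ethoxy at this place, or from methoxy on another carbon of the same ring. Also open, on these data alone, is whether the 2-methoxyphenoxy end gives a similar step with a longer chain leading to the amine.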